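Swapping a chlorophenyl for a butyl chain on a sulfur linker

This account rests on a few compounds, and the source may have more. Where it says the series, first, only, none or still open, it means among the compounds named here.

Measured so far:
compound 1, `CC(C)CSc1n[nH]c(-n2[se]c3ccccc3c2=O)n1`, 35000 nM
compound 2, `O=c1c2ccccc2[se]n1-c1nc(SCc2ccc(Cl)cc2)n[nH]1`, 33900 nM

In a functional assay on SMMC-7721 cells (Homo sapiens) for antiproliferative activity, read by CCK-8 assay, with a stated time of 48 h (a lower number here means a stronger inhibitor, a higher number a weaker inhibitor), compound 2 has the lower of the two numbers, but its gap to compound 1, a 1.0-fold lower number from compound 1 to compound 2 (0.01 log units; within the scatter), is within the scatter, so the two are indistinguishable. Compound 3, `CCCCCSc1n[nH]c(-n2[se]c3ccccc3c2=O)n1`, carries butyl in place of 4-chlorophenyl on a saturated chain carbon bound to a sulfur. Among the measured compounds shown here, the only step that bears on this place is that from compound 1 to compound 2, and it changed nothing beyond the scatter. Compound 3 is therefore expected to sit close to compound 2, with a step of a 1.0-fold higher number from compound 2 to compound 3 (0.00 log units; within the scatter), at an estimated 34000 nM, likely between 15000 nM and 75000 nM.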

Compound 3, half-maximal inhibitory concentration: 31400 nM
Estimate against measurement, compound 3: 1.1-fold (0.03 log units) above; the measured number falls inside the stated range.
By their numbers in this assay, from the lowest: compounds 3, 2 and 1 (each within the scatter of the next).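

In this assay, losing the aromatic ring and the chlorine of the 4-chlorophenyl group for a plain butyl chain gives a 1.1-fold lower number from compound 2 to compound 3 (0.03 log units; within the scatter) and butyl in place of isopropyl gives a 1.1-fold lower number from compound 1 to compound 3 (0.05 log units; within the scatter) at this place on a saturated chain carbon bound to a sulfur. Across these three compounds, then, a ring-bearing group and two open chains cannot be told apart by this read-out. Nothing available explains this result.

Going by these compounds, whether an amine, a carboxylic acid or a much longer chain at this place would shift the number stays open. So does whether changes to the shared core matter more than changes to this group.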